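A few compounds are considered here, and "the series" means these few. Any claim that something is new, unique, unknown or untested is made for them only; others in the source may bear on it.

Compound 1 `CCn1c(C(=O)N[C@@H](CC(=O)OC)C(=O)OC)ccc1C(CC)(CC)c1ccc(OCS(=O)(=O)c2ccccc2)c(C)c1`: > 50000 nM
Compound 2 `CCN(CC)CCNC(=O)c1ccc(C(CC)(CC)c2ccc(OCS(=O)(=O)c3ccccc3)c(C)c2)n1CC`: 4680 nM

Among the compounds with values here, in a functional assay on MCF7 cells (Homo sapiens) for antiproliferative activity, read by MTT assay, with a stated time of 24 h (a lower number here means a stronger inhibitor, a higher number a weaker inhibitor), compound 2 gives 4680 nM, the only true number so far. Compound 1 reads > 50000 nM, which is a limit of the assay and not a number.

Compound 3 `CCN(CC)CCNC(=O)c1ccc(C(CC)(CC)c2ccc(OCSC)c(C)c2)n1CC` keeps the 2-(diethylamino)ethyl group of compound 2 on the amide-type nitrogen. The change lies elsewhere: methylsulfanyl in place of phenylsulfonyl on a saturated chain carbon bound to an oxygen on an aromatic ring.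

Within the data shown here, only one measured step is available, and it bears on this change only indirectly. That step, an at least 10-fold lower number from compound 1 to compound 2 (1.02 log units; beyond the scatter), was large, but it took place on the amide-type nitrogen and not on the saturated chain carbon. Among the measured compounds shown here, it shows that one change can move this series far in this assay, yet no measured step shows the size or direction of a change at the new place. A swap that removes the phenylsulfonyl group could therefore matter, and a moderate move towards a weaker compound, starting from the 4680 nM of compound 2, is a cautious expectation. The expected size is a 1.7-fold higher number from compound 2 to compound 3 (0.23 log units; within the scatter). For compound 3 the estimated value is 8000 nM, with an expected range of 2000 nM to 30000 nM.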

Compound 3, half-maximal inhibitory concentration: 5160 nM
Compound 3: the middle estimate sits 1.6-fold (0.19 log units) above what was measured; the measured number falls inside the stated range.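

In this assay, the swap at the saturated chain carbon bound to an oxygen on an aromatic ring gives a 1.1-fold higher number from compound 2 to compound 3 (0.04 log units; within the scatter). Within the data shown here, this is the first measured step at this place, and it shows that phenylsulfonyl, with 9 heavy atoms and a six-membered aromatic ring, can give way to methylsulfanyl, with 2 heavy atoms and no ring, without a shift beyond the scatter, at least while 2-(diethylamino)ethyl stays on the amide-type nitrogen. Set against an at least 10-fold lower number from compound 1 to compound 2 (1.02 log units; beyond the scatter), the only other step shown, the change on the amide-type nitrogen stands out as the large one, although compound 1 rests on a limit and not a true number: the limit of > 50000 nM in this assay, at which 1 of the 3 values shown sits.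

Going by these compounds, these two groups are still a narrow sample of this place, so it remains open whether an amine, a carboxylic acid or a longer chain on that saturated carbon would also leave the number within the scatter. Also open, on these data alone, is whether methylsulfanyl would give the same result with the 1,2-bis(methoxycarbonyl)ethyl group of compound 1 on the amide-type nitrogen.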